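Changing the Core Substituent: Compound 4 in Acid Dissociation

This account rests on a few compounds, and the source may have more. Where it says the series, first, only, none or still open, it means among the compounds named here.

The measured compounds:
compound 1 `CC(C)CCc1ccc2c(NCCCNCc3ccco3)ccnc2c1`: 9.47
compound 2 `COc1ccc(F)cc1CNCCCNc1ccnc2cc(CCc3ccccc3)ccc12`: 9.47
compound 3 `c1ccc(CCc2ccc3c(NCCCNCc4ccco4)ccnc3c2)cc1`: 9.47

All three were measured in a physicochemical assay for acid dissociation. In this assay compound 2 gives 9.47, level with compounds 1 and 3 at the digits shown; its nearest neighbour is compound 1 and its furthest is compound 3, and neither gap reaches beyond the scatter. Among the measured compounds shown here, the two steps that connect the set are no change at the digits printed from compound 1 to compound 3 (within the scatter) and no change at the digits printed from compound 2 to compound 3 (within the scatter); the first alters the group on the shared core, the second the group on the saturated chain carbon bound to the amine nitrogen, and neither shifts the read-out.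

Compound 4 `COc1ccc(F)cc1CNCCCNc1ccnc2cc(Oc3ccc(Cl)cc3)ccc12` has not yet been measured. It arises from compound 2 by 4-chlorophenoxy in place of phenethyl on an aromatic carbon. This change sits on the shared core, the same region that is altered from compound 1 to compound 3, where no change was seen. The two steps that bear on it were both flat, so no step beyond the scatter is expected in this assay.

For compound 4, then, the expected value in this assay is 9.45 (range 9.15 to 9.75), meaning a step of a number 0.02 log units lower from compound 2 to compound 4 (within the scatter) that is expected to fall within the scatter.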

Compound 4, acid dissociation constant: 9.28
Compound 4: middle estimate off by 0.17 log units, on the high side; the range from low to high includes it.
By their numbers in this assay, from the lowest: compounds 4, 1, 2 and 3 (each within the scatter of the next).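

In this assay, placing 4-chlorophenoxy in place of phenethyl on the aromatic carbon gives a number 0.19 log units lower from compound 2 to compound 4 (within the scatter) and so stays within the scatter. The earlier step on the shared core, no change at the digits printed from compound 1 to compound 3 (within the scatter) and also within the scatter, altered only a group further along a saturated chain, whereas this change replaces the whole group on the aromatic carbon, bringing in oxygen, chlorine and a hydrogen-bond acceptor that phenethyl lacks, and the read-out still shows no step beyond the scatter. Nothing available bears on why this exchange leaves the read-out within the scatter.

The compounds shown leave open whether the oxygen or the chlorine of 4-chlorophenoxy contributes anything on its own, which unsubstituted phenoxy or 4-chlorophenethyl at the same carbon could separate. On these data alone, both groups at this position also carry a six-membered aromatic ring of carbon only, so it remains open whether an amine, a carboxylic acid or a small group such as methoxy on this aromatic carbon would also stay within the scatter.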